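Removing tert-butoxycarbonyl from compound 3

The compounds below may be only part of what the source reports. "The series", "measured", "known", "first", "only" and "open" are said of these compounds alone.

In a functional assay on K562 cells (Homo sapiens) for inhibition, read by MTT assay, with a stated time of 48 h (a higher number here means a weaker inhibitor, a lower number a stronger inhibitor), three compounds have values:
Compound 1 `O=C(Nc1ccc(-c2cn([C@@H]3CN[C@H](C(=O)Nc4ccc(Cl)c(C(F)(F)F)c4)C3)nn2)cn1)C1CC1` gives 8770 nM
Compound 2 `CS(=O)(=O)Nc1ccc(-c2cn([C@@H]3CN[C@H](C(=O)Nc4ccc(Cl)c(C(F)(F)F)c4)C3)nn2)cn1` gives 5060 nM
Compound 3 `CC(C)(C)OC(=O)N1C[C@@H](n2cc(-c3ccc4nc(N)sc4n3)nn2)C[C@H]1C(=O)Nc1ccc(Cl)c(C(F)(F)F)c1` gives 10900 nM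

Compound 3 lies within the usual scatter of compound 1, while its number sits above that of compound 2 by a gap just beyond the scatter. Compound 4 `Nc1nc2ccc(-c3cn([C@@H]4CN[C@H](C(=O)Nc5ccc(Cl)c(C(F)(F)F)c5)C4)nn3)nc2s1` is compound 3 with one change (hydrogen in place of tert-butoxycarbonyl on an amine nitrogen in a ring), hydrogen in place of tert-butoxycarbonyl on an amine nitrogen in a ring.

Going by the values given here, no measured step makes this change. Among the compounds with values here, the only step available, a 1.7-fold lower number from compound 1 to compound 2 (0.24 log units; within the scatter), is small and sits on a nitrogen on an aromatic ring, elsewhere in the molecule. Indirect help comes from compound 1 (8770 nM) and compound 2 (5060 nM), which already carry hydrogen on the amine nitrogen in a ring and give numbers of the same order as compound 3. They differ from compound 4 in their other groups, so this guide is loose. A step beyond the scatter is therefore not expected, and any drift should be towards a lower number. The expected change is a 1.6-fold lower number from compound 3 to compound 4 (0.19 log units; within the scatter) in this assay as an estimate. The estimate for compound 4 is 7000 nM with an expected range from 2500 nM to 18000 nM as its ends.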

Compound 4, half-maximal inhibitory concentration: 26200 nM
Estimate against measurement, compound 4: 3.7-fold (0.57 log units) below, and the stated range ends below it.
By their numbers in this assay, from the lowest: compounds 2, 1 and 3 (each within the scatter of the next, the first and the last beyond it); then compound 4.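

In this assay, hydrogen in place of tert-butoxycarbonyl on the amine nitrogen in a ring gives a 2.4-fold higher number from compound 3 to compound 4 (0.38 log units; beyond the scatter) and so moves the number up, beyond the scatter, which makes compound 4 a weaker inhibitor than compound 3 in this pair. Compounds 1 and 2 could not show this, as both already carry that hydrogen, but compound 4 now adds a second comparison at the aromatic carbon with the same hydrogen in place: a 5.2-fold higher number from compound 2 to compound 4 (0.71 log units; beyond the scatter) and, in the same direction, a 3.0-fold higher number from compound 1 to compound 4 (0.48 log units; beyond the scatter), so the group with the five-membered aromatic ring goes with the higher number in both pairs. Nothing measured here accounts for either rise.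

The compounds shown leave open whether the upward step comes from losing tert-butoxycarbonyl in particular or would follow the loss of any group on that nitrogen, and a methyl or an acetyl group there would help separate the two. They also leave open whether the same step would appear with the cyclopropylcarbonyl or methylsulfonyl groups of compounds 1 and 2 elsewhere in the molecule.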